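A few compounds are considered here, and "the series" means these few. Any claim that something is new, unique, unknown or untested is made for them only; others in the source may bear on it.

Of the compounds shown here, two have so far been measured in a functional assay, with a stated time of 30 min, tested at 1 mM; on this read-out lower numbers stand for less inhibition and higher numbers for more inhibition at the one concentration tested (going by the name of the read-out). Compound 1 `COc1ccc(/C=C/C(=O)NC(=O)c2ccccc2)cc1O` gives 7.02%. Compound 2 `O=C(/C=C/c1ccc(O)c(Br)c1)NC(=O)c1ccccc1` gives 17.3%, the higher of the two numbers, and its distance from compound 1 lies beyond the usual scatter of repeated measurements of this kind. Going by the values given here, no pair of measured compounds differs in only one place, so no single-change step has been observed directly.

Compound 3 `O=C(/C=C/c1cc(Br)c(O)c(Br)c1)NC(=O)c1ccccc1` has not yet been measured. It differs from compound 2 in one place: bromo in place of hydrogen on an aromatic carbon. The entering bromo sits on an aromatic carbon of a six-membered aromatic ring of carbon only, ortho to a hydroxy group and meta to the bromo group that compound 2 already carries.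

Among the compounds with values here, with only two numbers available, the expectation rests on compound 2, whose 17.3% is the starting point. A second bromo is expected to move the number upward, but only modestly, and the change may stay within the scatter. The estimate for compound 3 is 25%, within a range from 10% to 45%. The step this estimate implies, a number 7.7 percentage points higher from compound 2 to compound 3 (within the scatter), is an expectation rather than a measurement.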

Compound 3, a percentage reported as inhibition, at one concentration (the size of the read-out at that concentration, not a potency): "not active" (no number reported)
Compound 3 has no reported number here; there is nothing to compare the estimate with.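

In this assay, going by these compounds alone, compound 3 is reported only as not active, with no number, so no step from compound 2 to compound 3 can be read. These compounds leave open how far the added bromo changes the inhibition compared with compound 2. Nothing shown here offers an explanation for this result.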